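The source may report more compounds than this note shows. Statements on the series, on what has been measured and on what is new or still open speak of the compounds shown alone.

Series notes. Compound 2 `CSc1ccc(C(=O)/C=C/c2ccc3c(c2)B(O)OC3)cc1` is the weaker of the two compounds measured in a toxicity assay on WI-38 cells (Homo sapiens) for cytotoxicity, read by MTT assay, with a stated time of 48 h; a lower number here means a stronger inhibitor, a higher number a weaker inhibitor: compound 2 gives 54300 nM, the higher of the two numbers. Compound 1 `CCc1ccc(C(=O)/C=C/c2ccc3c(c2)B(O)OC3)cc1` gives 20600 nM in this assay. Among the compounds with values here, the only measured step is a 2.6-fold higher number from compound 1 to compound 2 (0.42 log units; beyond the scatter).

Compound 3 `O=C(/C=C/c1ccc2c(c1)B(O)OC2)c1ccc(O)cc1` has not yet been measured; the change from compound 2 is hydroxy in place of methylsulfanyl on an aromatic carbon. Within the data shown here, no measured step covers this exact change. Among the measured compounds shown here, the one step available, ethyl to methylsulfanyl at the same place, moved the number modestly, so a change at this position is expected to move the number by a comparable modest amount at most; the direction cannot be read from the data, and a step within the scatter is as likely as one beyond it. The expected step for compound 3 is a 1.4-fold lower number from compound 2 to compound 3 (0.13 log units; within the scatter) in this assay, with a wide range owing to the missing precedent. Compound 3 is estimated at 40000 nM in this assay, between 15000 nM and 110000 nM.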

Compound 3, half-maximal inhibitory concentration: > 100000 nM
Compound 3: a limit, no number; the forecaster's own chance of this, stated with the estimate: 15%; at least 2.5-fold (0.39 log units) between middle value and limit.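

The reading for compound 3 is a limit of the assay and not a number: the limit of > 100000 nM in this assay, at which 1 of the 3 values shown sits. In this assay, hydroxy in place of ethyl gives an at least 4.8-fold higher number from compound 1 to compound 3 (0.68 log units; beyond the scatter), a wider span at this position than the modest step seen earlier, and one that clears the scatter. Hydroxy in place of methylsulfanyl gives an at least 1.8-fold higher number from compound 2 to compound 3 (0.26 log units; that floor lies within the scatter), so that floor alone does not separate these two groups, although hydroxy brings a hydrogen-bond donor where methylsulfanyl has none.

How far compound 3 lies past its limit remains unread, and so does the true size of both steps. Also open, on these data alone, is whether a methoxy group or an amine on this aromatic carbon would sit with hydroxy or nearer to ethyl.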